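The source may report more compounds than this note shows. Statements on the series, on what has been measured and on what is new or still open speak of the compounds shown alone.

Measured compounds in a functional assay on MDA-MB-231 cells (Homo sapiens) for antiproliferative activity, read by MTT assay, with a stated time of 24 h; on this read-out lower numbers stand for stronger inhibition and higher numbers for weaker inhibition:
- compound 1, `COc1cc(-c2cc(C(=O)/C=C/c3ccccc3)nc3cc(-c4ccccc4)nn23)cc(OC)c1OC`, gives 19200 nM
- compound 2, `COc1cc(-c2cc(/C=C/C(=O)c3ccc(C)cc3)nc3cc(-c4ccccc4)nn23)cc(OC)c1OC`, gives 23900 nM
- compound 3, `COc1cc(-c2cc(/C=C/C(=O)c3ccccc3)nc3cc(-c4ccccc4)nn23)cc(OC)c1OC`, gives 15800 nM

Compound 3 carries the lowest of the three numbers, but its distance from the others is small: a 1.2-fold lower number from compound 1 to compound 3 (0.08 log units; within the scatter) and a 1.5-fold lower number from compound 2 to compound 3 (0.18 log units; within the scatter) both sit within the scatter, so no order among compounds 1, 2 and 3 can be read from this assay. The three compounds share the same core and differ only in how the enone is attached and in what sits on its aryl ring.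

Compound 4, `COc1cc(-c2cc(/C=C/C(=O)c3ccc(C)c(C)c3)nc3cc(-c4ccccc4)nn23)cc(OC)c1OC`, is not yet measured. Relative to compound 3 the change is 3,4-dimethylphenyl in place of phenyl on a carbonyl carbon. Among the measured compounds shown here, the one measured step that bears on this is a 1.5-fold lower number from compound 2 to compound 3 (0.18 log units; within the scatter), where the removal of a single methyl from the aryl ring of the ketone did not move the number beyond the scatter. Compound 4 adds two methyls to that ring; on the evidence of compound 2 against compound 3, no step beyond the scatter is expected, with at most a slight drift toward a higher number.

For compound 4 the estimate in this assay is 20000 nM, with a range from 10000 nM to 40000 nM. The expected step is therefore a 1.3-fold higher number from compound 3 to compound 4 (0.10 log units; within the scatter), within the scatter.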

Compound 4, half-maximal inhibitory concentration: 13500 nM
Beside the measured number, compound 4's estimate is 1.5-fold (0.17 log units) above it; measured number inside the range.
By their numbers in this assay, from the lowest: compounds 4, 3, 1 and 2 (each within the scatter of the next).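

In this assay, 3,4-dimethylphenyl in place of phenyl on the carbonyl carbon gives no readable step (a 1.2-fold lower number from compound 3 to compound 4 (0.07 log units; within the scatter)), and the same holds for the added methyl on the 4-methylphenyl ring (a 1.8-fold lower number from compound 2 to compound 4 (0.25 log units; within the scatter)). The aryl ring of the ketone has now carried no methyl, one methyl and two methyls with every step inside the scatter, so this position accepts 3,4-dimethylphenyl in this read-out and no trend with methyl count can be claimed. The comparison with the other enone attachment, 2-((3,4-dimethylphenyl)carbonyl)ethenyl in place of (2-phenylethenyl)carbonyl, also stays inside the scatter (a 1.4-fold lower number from compound 1 to compound 4 (0.15 log units; within the scatter)), and no supporting measurement is available to account for any of these numbers.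

All the groups shown on this ring are phenyl with or without methyl, so it remains open whether an amine or a carboxylic acid there would give a step beyond the scatter. As far as these compounds go, it also remains open whether a saturated chain in place of the enone, with the shared core kept, would move the number at all.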